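Swapping a Naphthalene for a Trifluoromethylphenyl Group

A few compounds are considered here, and "the series" means these few. Any claim that something is new, unique, unknown or untested is made for them only; others in the source may bear on it.

Compound 1, `Cc1nc(-c2ccccc2)oc1COc1ccc2c(c1)OCC2CC(=O)O`, gives 7.15% in a functional assay on CHO cells for agonist activity at Free fatty acid receptor 1 (Homo sapiens), read by FLIPR and calcium flux, tested at 100 nM; on this read-out higher numbers stand for a stronger effect at the one concentration tested and lower numbers for a weaker effect.
Compound 2, `Cc1nc(-c2cccc3ccccc23)sc1COc1ccc2c(c1)OCC2CC(=O)O`, gives 8.53% in this assay.

Both measured compounds share the same core and differ only in the aromatic group attached to the five-membered ring. Compound 2 gives the larger of the two numbers, yet the gap to compound 1 lies within the scatter, so the two cannot be told apart on this read-out; both sit near the bottom of the scale.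

Compound 3, `Cc1nc(-c2ccc(C(F)(F)F)cc2)sc1COc1ccc2c(c1)OCC2CC(=O)O`, has not yet been measured. It differs from compound 2 in one place: 4-(trifluoromethyl)phenyl in place of naphthalen-1-yl on an aromatic carbon.

Within the data shown here, no step between measured compounds is available to guide the expectation, and the two measured values are both small and alike. The step of a number 0.5 percentage points higher from compound 2 to compound 3 (within the scatter) is therefore expected to be none beyond the scatter, with the new compound remaining a weak activator at the single concentration tested.

For compound 3 the read-out in this assay is estimated at 9%, with a range from 0% to 25%.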

Compound 3, a percentage reported as activity, at one concentration (the size of the read-out at that concentration, not a potency): 50.4%
The estimate for compound 3 lay 41.4 percentage points below the measured number; measured number above the stated range.
By their numbers in this assay, from the lowest: compounds 1 and 2 (each within the scatter of the next); then compound 3.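

In this assay, the group on this aromatic carbon, next to the ring nitrogen and next to the ring sulfur, strongly affects the read-out: with the rest of the molecule unchanged, putting 4-(trifluoromethyl)phenyl in place of naphthalen-1-yl gives a number 41.9 percentage points higher from compound 2 to compound 3 (beyond the scatter). The two groups have the same count of heavy atoms, and neither has hydrogen-bond donors, hydrogen-bond acceptors or a net charge, so these counts do not separate them; the visible differences are one aromatic ring instead of two and the presence of fluorine. No measurement at hand gives a reason for a step of this size.

Compound 3 differs from compound 2 in both ring count and fluorine at once, so the compounds shown cannot say which of the two differences goes with the higher number. A 4-chlorophenyl or 4-methoxyphenyl group at this position would show whether other single-ring groups give a similar read-out, and measurements at further concentrations would show whether the stronger effect seen at this one concentration holds at others.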